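Homologating a hydantoin side chain: an expected permeability

The compounds below may be only part of what the source reports. "The series", "measured", "known", "first", "only" and "open" are said of these compounds alone.

Measured compounds:
- compound 1 `CC(C)/C(=C1\C(=O)NC(=O)N1C)c1ccc(-c2ccc3cccc(F)c3c2)[nH]c1=O`: 6.85 10^-6 cm/s
- compound 2 `CC(C)C(c1ccc(-c2ccc3cccc(F)c3c2)[nH]c1=O)C1C(=O)NC(=O)N1C`: "not determined" (no result reported)

Compound 1 `CC(C)/C(=C1\C(=O)NC(=O)N1C)c1ccc(-c2ccc3cccc(F)c3c2)[nH]c1=O` was tested in an ADME assay on MDCK cells (Canis lupus familiaris) for permeability, in the apical to basolateral direction (on this read-out higher numbers stand for higher permeability and lower numbers for lower permeability), and gives 6.85 10^-6 cm/s. Compound 2 `CC(C)C(c1ccc(-c2ccc3cccc(F)c3c2)[nH]c1=O)C1C(=O)NC(=O)N1C` shares the core of compound 1 but carries a saturated link to its hydantoin ring instead of a double bond; in this assay compound 2 is recorded as "not determined" (no result reported), so its standing can only be read by analogy to compound 1. Compound 3 `CC(C)C(CC1C(=O)NC(=O)N1C)c1ccc(-c2ccc3cccc(F)c3c2)[nH]c1=O` is a close relative of compound 2, differing in one place: (3-methyl-2,5-dioxoimidazolidin-4-yl)methyl in place of 3-methyl-2,5-dioxoimidazolidin-4-yl on a saturated chain carbon bound to an aromatic carbon and a saturated chain carbon The change inserts a single chain carbon and leaves the ring and its hydrogen-bond donor and acceptors as counted. Among the compounds with values here, no measured step of this kind exists here, so the expected shift in this assay is small, within the scatter or modestly upward. Compound 3 is therefore estimated at 8 10^-6 cm/s, with a range from 3 10^-6 cm/s to 20 10^-6 cm/s, because compound 1 gives 6.85 10^-6 cm/s and no larger change is indicated.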

Compound 3, apparent permeability: 17.6 10^-6 cm/s
For compound 3 the middle estimate is 2.2-fold (0.34 log units) below the measured one; low and high end bracket the measured number.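

Within the data shown here, compound 2 has no number to set against compound 3 in this assay and so no step between them can be read. From the compounds shown here alone, what the extra chain carbon does to this read-out stays open. Nothing available here explains the value of compound 3.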